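The source may report more compounds than this note shows. Statements on the series, on what has been measured and on what is new or still open speak of the compounds shown alone.

Measured so far in an assay on CHO cells for displacement of a labelled ligand from adenosine receptor A1 (Homo sapiens); on this read-out lower numbers stand for stronger inhibition and higher numbers for weaker inhibition:
- compound 1 `CONc1nc(C#CC2CCCCC2O)nc2c1ncn2[C@@H]1O[C@H](CO)[C@@H](O)[C@H]1O` gives 34 nM
- compound 2 `CONc1nc(C#Cc2cccnc2)nc2c1ncn2[C@@H]1O[C@H](CO)[C@@H](O)[C@H]1O` gives 255 nM

Among the compounds with values here, compound 2 gives the higher of the two numbers, so it binds more weakly than compound 1; the only step measured, a 7.5-fold higher number from compound 1 to compound 2 (0.88 log units; beyond the scatter), shows that swapping the 2-hydroxycyclohexyl group for an aromatic ring cost binding. Compound 3 `CONc1nc(C#Cc2cccc(C(F)(F)F)c2)nc2c1ncn2[C@@H]1O[C@H](CO)[C@@H](O)[C@H]1O` differs from compound 2 by 3-(trifluoromethyl)phenyl in place of pyridin-3-yl on a triple-bonded carbon. Within the data shown here, no measured step covers an exchange of one aromatic ring for another, so the direction is uncertain; the expected step in this assay is therefore small, a 1.3-fold lower number from compound 2 to compound 3 (0.11 log units; within the scatter), with a wide range. Compound 3 is estimated at 200 nM, between 50 nM and 800 nM.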

Compound 3, inhibition constant: 2450 nM
For compound 3 the middle estimate is 12-fold (1.09 log units) below the measured one, and the stated range ends below it.
By their numbers in this assay, from the lowest: compound 1; then compound 2; then compound 3.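

In this assay, exchanging one aromatic ring for another on the triple-bonded carbon is far from neutral: 3-(trifluoromethyl)phenyl in place of pyridin-3-yl gives a 9.6-fold higher number from compound 2 to compound 3 (0.98 log units; beyond the scatter), so the identity of the ring matters here. Measured against the 2-hydroxycyclohexyl group, the same group gives a 72-fold higher number from compound 1 to compound 3 (1.86 log units; beyond the scatter), the largest step in this set. Nothing available explains this loss.

From the compounds shown here alone, this step removes the ring nitrogen and adds trifluoromethyl together, so their separate contributions remain unknown. An unsubstituted phenyl ring would separate them, and a straight hydroxyalkyl chain would test whether the cyclohexyl ring is needed.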